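Swapping Chlorines for Methyls on the Aryl Ring

This account rests on a few compounds, and the source may have more. Where it says the series, first, only, none or still open, it means among the compounds named here.

Two compounds have so far been run in an ADME assay on microsomes from liver (Rattus norvegicus) for metabolic stability, read by LC-MS, using NADPH, at 37 degrees C; a higher number here means that the compound lasts longer, a lower number that the compound disappears faster. Compound 1 `Cc1ccccc1-c1nc(CN2CCC(C(=O)NCCCN3CC(C)(C)CC(C)(C)C3)CC2)c(C)o1` carries a 2-methylphenyl group on the shared core and a tetramethyl-substituted piperidine at the end of its chain; in this assay compound 1 gives 0.095 h. Compound 2 `Cc1oc(-c2ccc(Cl)c(Cl)c2)nc1CN1CCC(C(=O)NCCCN2C[C@H](C)C[C@H](C)C2)CC1` carries a 3,4-dichlorophenyl on the same core and a dimethyl-substituted piperidine. For compound 2 this assay reports only a limit, > 0.5 h, not a number. Compound 2 therefore stands at the limit of > 0.5 h in this assay, at which 1 of the 2 values shown sits, while compound 1 stands well inside the measurable range.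

Compound 3 `Cc1ccc(-c2nc(CN3CCC(C(=O)NCCCN4C[C@H](C)C[C@H](C)C4)CC3)c(C)o2)cc1C` has not yet been measured. It differs from compound 2 in a single place: 3,4-dimethylphenyl in place of 3,4-dichlorophenyl on an aromatic carbon. No measured pair shows this exact exchange, so the expected direction rests on judgement rather than on a shown step. The change from compound 2 to compound 3 is expected to be a fall of moderate size, an at least 1.6-fold lower number from compound 2 to compound 3 (0.22 log units; that floor lies within the scatter), beyond the usual scatter. Compound 3 is estimated at 0.3 h, with a range from 0.1 h to 0.6 h.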

Compound 3, half-life: > 0.5 h
Compound 3: a limit, no number (the forecaster's own chance of this, stated with the estimate: 25%); middle value at least 1.6-fold (0.22 log units) away from the limit.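

Compound 2 and compound 3 both give a limit rather than a number in this assay, so no step can be read between them: the limit of > 0.5 h in this assay, at which 2 of the 3 values shown sit.

The compounds shown leave open whether 3,4-dimethylphenyl in place of 3,4-dichlorophenyl changes the half-life at all, and if it does, in which direction and by how much.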